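The source may report more compounds than this note shows. Statements on the series, on what has been measured and on what is new or still open speak of the compounds shown alone.

In a functional assay on BGC-823 cells (Homo sapiens) for inhibition, read by MTT assay, with a stated time of 72 h (a lower number here means a stronger inhibitor, a higher number a weaker inhibitor), compound 1 `O=C(NCc1ccc(NC(=O)c2cc(F)ccc2N2CCCC2)cc1)OCc1cccnc1` gives 14800 nM as a measured number. Compound 2 `O=C(NCc1ccc(NC(=O)c2cc(Cl)ccc2N2CCCC2)cc1)OCc1cccnc1` gives > 100000 nM and this is a limit of the assay, not a number. Compound 3 `O=C(NCc1ccc(NC(=O)c2cc(C(F)(F)F)ccc2N2CCCC2)cc1)OCc1cccnc1` carries trifluoromethyl in place of chloro on an aromatic carbon. Among the measured compounds shown here, the only measured step at this carbon, chloro in place of fluoro, is an at least 6.7-fold higher number from compound 1 to compound 2 (0.82 log units; beyond the scatter) and lies beyond the scatter. That one step from compound 1 sets no clear direction for a further exchange, so in this assay no step beyond the scatter is expected, estimated as an at least 1.6-fold lower number from compound 2 to compound 3 (0.22 log units; that floor lies within the scatter) here. For compound 3 the estimated value is 60000 nM with an expected range of 15000 nM to 200000 nM in this assay.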

Compound 3, half-maximal inhibitory concentration: > 100000 nM
Compound 3 ended at the assay's limit; the forecaster's own chance of this, stated with the estimate: 45%; middle value at least 1.6-fold (0.22 log units) from the limit.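

Trifluoromethyl in place of fluoro gives an at least 6.7-fold higher number from compound 1 to compound 3 (0.82 log units; beyond the scatter) in this assay, so a second replacement for fluoro at this aromatic carbon also leaves no measured number. Among the three groups shown here, only fluoro gives one. The step from compound 2 to compound 3 cannot be read, because both compounds sit at the same limit: the limit of > 100000 nM in this assay, at which 2 of the 3 values shown sit.

Still open, as far as these compounds go, is whether an amine, a methoxy group or a plain hydrogen at this carbon would give a measured number, and whether any group would give a lower number than fluoro.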